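The source may report more compounds than this note shows. Statements on the series, on what has been measured and on what is new or still open speak of the compounds shown alone.

Measured compounds:
Compound 1, `CCN(CCn1cc[n+](C)c1/C=N/O)S(C)(=O)=O`: -2.72
Compound 2, `C[n+]1ccn(CCNS(=O)(=O)C(F)(F)F)c1/C=N/O`: -1.2

Of the compounds shown here, two have been measured in a physicochemical assay for lipophilicity; on this read-out higher numbers stand for higher lipophilicity and lower numbers for lower lipophilicity. In this assay compound 1 gives -2.72 and compound 2 gives -1.2. Compound 2 therefore stands highest of the two numbers, and the nearest value, that of compound 1, lies lower by a gap beyond the scatter. Going by the values given here, the two structures differ in more than one place, so no single structural step connects them and the two values are taken only as they stand.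

Compound 3, `CCN(CCn1cc[n+](C)c1/C=N/O)S(=O)(=O)C(F)(F)F`, is not yet measured. It differs from compound 2 by ethyl in place of hydrogen on a sulfonamide nitrogen. Among the compounds with values here, no measured pair in this set shows the effect of exactly this change, so its size has to be estimated. The account expects a step upward in this assay, of moderate size and beyond the scatter, as a number 0.70 log units higher from compound 2 to compound 3 (beyond the scatter). For compound 3 the estimated value in this assay is -0.5, with a range from -1.3 to 0.3.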

Compound 3, distribution coefficient: -1.03
Beside the measured number, compound 3's estimate is 0.53 log units above it; low and high end bracket the measured number.
By their numbers in this assay, from the lowest: compound 1; then compounds 2 and 3 (each within the scatter of the next).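

In this assay, ethyl in place of hydrogen on a sulfonamide nitrogen gives a number 0.17 log units higher from compound 2 to compound 3 (within the scatter), so at this position, with trifluoromethyl on the sulfonyl sulfur, the two compounds cannot be told apart and the added ethyl leaves no readable mark on the number. Compound 3 also gives the set its first connection to compound 1: with ethyl on the sulfonamide nitrogen in both compounds, trifluoromethyl in place of methyl on a sulfonyl sulfur gives a number 1.69 log units higher from compound 1 to compound 3 (beyond the scatter), so among these three compounds the one large step lies at the sulfonyl sulfur and not at the sulfonamide nitrogen. No measurement at hand offers an explanation for either step.

The compounds shown leave open whether a longer chain, such as butyl, or a benzyl group on the sulfonamide nitrogen would also stay within the scatter of compound 2, and whether ethyl in place of hydrogen would give a similar result with methyl on the sulfonyl sulfur. They also leave open what lies between methyl and trifluoromethyl at the sulfonyl sulfur, for instance a difluoromethyl group, or what a phenyl group there would give.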